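Replacing the Ring Methyl with a Cyclopropylcarbonyl Group

This account rests on a few compounds, and the source may have more. Where it says the series, first, only, none or still open, it means among the compounds named here.

Of the compounds shown here, three sharing one core have been tested in an assay on HEK293 cells for negative allosteric modulation of metabotropic glutamate receptor 5 (Homo sapiens), read by FLIPR, with a stated time of 1 h; on this read-out higher numbers stand for weaker inhibition and lower numbers for stronger inhibition. In this assay compound 1 `Cc1cccc(C#Cc2nc3c(s2)C(=O)NCC3)c1` reaches only the limit > 10000 nM. Compound 2 `CN1CCc2nc(C#Cc3ccccc3)sc2C1` bears a methyl on the amine nitrogen in its ring, and in this assay compound 2 likewise sits at the limit > 10000 nM. Compound 3 `CN1CCc2nc(C#Cc3cccc(F)c3)sc2C1` differs from compound 2 by a fluoro in place of a hydrogen on an aromatic carbon, and in this assay compound 3 gives the limit > 10000 nM. The step that the two limits leave unreadable from compound 2 to compound 3 therefore cannot be read, and all three values rest on the same boundary (the limit of > 10000 nM in this assay, at which 3 of the 3 values shown sit). Among the compounds with values here, compound 2 thus stands at that boundary together with the other two compounds, and no measured step has yielded a number.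

The untested compound 4 `O=C(C1CC1)N1CCc2nc(C#Cc3ccccc3)sc2C1` arises from compound 2 by cyclopropylcarbonyl in place of methyl on an amine nitrogen in a ring. Within the data shown here, no measured step covers this change, and the step from compound 2 to compound 3 gives no size. The expectation for compound 4 is accordingly a loose one: a step of an at least 1.6-fold lower number from compound 2 to compound 4 (0.22 log units; that floor lies within the scatter) is expected, with some chance of moving toward stronger inhibition, but held with little confidence. In this assay compound 4 is expected near 6000 nM, with a range from 800 nM to 30000 nM.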

Compound 4, half-maximal inhibitory concentration: 290 nM
Compound 4: the middle estimate sits 21-fold (1.32 log units) above what was measured; the measured number lies below the stated range.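

Cyclopropylcarbonyl in place of methyl on the amine nitrogen in the ring gives, in this assay, an at least 34-fold lower number from compound 2 to compound 4 (1.53 log units; beyond the scatter). That size is only a floor, because compound 2 rests on a limit of the assay and not on a number: the limit of > 10000 nM in this assay, at which 3 of the 4 values shown sit. Within the data shown here, until now the one step among the earlier compounds could not be read, so this amine nitrogen is the first place in the set where a change shows a size, and the only number below that limit comes with the cyclopropylcarbonyl group of compound 4.

What the compounds shown leave open is whether the step belongs to the carbonyl or to the three-membered ring, a question that an acetyl group or a cyclopropylmethyl group on the same nitrogen would separate. Also open, as far as these compounds go, is whether a fluoro on an aromatic carbon, whose step could not be read with the methyl in place, would show a readable step when set on compound 4, where the starting value is a number and not a limit.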